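Adding methyl to the sulfonyl ring of compound 3

A few compounds are considered here, and "the series" means these few. Any claim that something is new, unique, unknown or untested is made for them only; others in the source may bear on it.

In a functional assay on MCF7 cells (Homo sapiens) for antiproliferative activity, read by MTT assay, with a stated time of 24 h (a higher number here means a weaker inhibitor, a lower number a stronger inhibitor), compound 1 `Cc1ccc(-c2nn(-c3ccccc3)cc2-c2nc3ccccc3[nH]2)cc1` gives 7260 nM and compound 2 `FC(F)(F)c1ccc(-c2nn(-c3ccccc3)cc2-c2nc3ccccc3[nH]2)cc1` gives 6330 nM in the same read-out. Compound 3 `Cc1ccc(-c2nn(-c3ccccc3)cc2-c2nc3ccccc3n2S(=O)(=O)c2ccccc2)cc1` at 830 nM has the lowest of the three numbers, and its gaps to both others lie beyond the scatter. Phenylsulfonyl in place of hydrogen on an aromatic nitrogen gave an 8.7-fold lower number from compound 1 to compound 3 (0.94 log units; beyond the scatter) as the larger measured step.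

Compound 4 `Cc1ccc(-c2nn(-c3ccccc3)cc2-c2nc3ccccc3n2S(=O)(=O)c2ccc(C)cc2)cc1` carries methyl in place of hydrogen on an aromatic carbon and so turns phenylsulfonyl to (4-methylphenyl)sulfonyl. Among the measured compounds shown here, no measured step alters that group once it is in place. The closest guide is the trifluoromethyl in place of methyl change on an aromatic carbon, which gave a 1.1-fold lower number from compound 1 to compound 2 (0.06 log units; within the scatter) and stayed small. No step beyond the scatter is therefore expected in this assay for this change. The expected step is a 1.1-fold lower number from compound 3 to compound 4 (0.04 log units; within the scatter) and is only an estimate. Compound 4 is estimated at 760 nM with an expected range from 320 nM to 1800 nM in this read-out.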

Compound 4, half-maximal inhibitory concentration: 570 nM
The estimate for compound 4 lay 1.3-fold (0.12 log units) above the measured number, within the range that was stated.
By their numbers in this assay, from the lowest: compounds 4 and 3 (each within the scatter of the next); then compounds 2 and 1 (each within the scatter of the next).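

In this assay, methyl on an aromatic carbon of the sulfonyl ring, para to a large group, gives a 1.5-fold lower number from compound 3 to compound 4 (0.16 log units; within the scatter), so this position accepts methyl without a change beyond the scatter. The sulfonyl effect persists with the added methyl: (4-methylphenyl)sulfonyl in place of hydrogen on the aromatic nitrogen gives a 13-fold lower number from compound 1 to compound 4 (1.11 log units; beyond the scatter), a step of the same direction as an 8.7-fold lower number from compound 1 to compound 3 (0.94 log units; beyond the scatter). No measurement at hand bears on what underlies either the sulfonyl steps or the small methyl step.

Open, going by these compounds, is whether an amine, a carboxylic acid or a longer chain on that same ring carbon would stay within the scatter of compound 3. Also open, on these data alone, is whether a sulfonyl group on the ring nitrogen of compound 2, with its trifluoromethyl, would give a comparable step.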